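The source may report more compounds than this note shows. Statements on the series, on what has been measured and on what is new or still open speak of the compounds shown alone.

Measured so far in a functional assay on the whole organism (artery, strain albino) with Rattus norvegicus as the target, with a stated time of 240 min, at a dose of 10 mg/kg by the oral route; a lower number here means less inhibition, a higher number more inhibition at the dose given (going by the name of the read-out):
compound 1 `CC1=C(C(=O)Nc2ccc(Br)cc2)C(c2ccc(Cl)cc2Cl)N=C(SCc2ccccc2Cl)N1`: 28.7%
compound 2 `CC1=C(C(=O)Nc2ccc(Br)cc2)C(c2ccc(Cl)cc2Cl)N=C(SCc2cccc(Cl)c2)N1`: 15.9%

Among the measured compounds shown here, compound 2 stands lowest of these two numbers; the only neighbour is compound 1, and the step of a number 12.8 percentage points lower from compound 1 to compound 2 (beyond the scatter) lies beyond the scatter. Compound 3 `CC1=C(C(=O)Nc2ccc(Br)cc2)C(c2ccc(Cl)cc2Cl)N=C(SCc2ccc(F)cc2)N1` differs from compound 2 in one place: 4-fluorophenyl in place of 3-chlorophenyl on a saturated chain carbon bound to a sulfur.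

For the measured compounds named here, only one measured step touches this region of the structure, a number 12.8 percentage points lower from compound 1 to compound 2 (beyond the scatter), and it concerns chlorophenyl groups alone; nothing measured contains a fluorophenyl group here. That step shows that changes on this ring can shift this assay by a modest amount, but it gives no direction for the present change. The expected step of a number 4.1 percentage points higher from compound 2 to compound 3 (within the scatter) is therefore modest, with a wide range in either direction. Compound 3 is estimated to give 20% in this assay, expected to fall between 5% and 38%.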

Compound 3, a percentage reported as inhibition, in the whole organism at one dose (the size of the read-out at that dose, not a potency): 36.4%
For compound 3 the middle estimate is 16.4 percentage points below the measured one; low and high end bracket the measured number.
By their numbers in this assay, from the lowest: compound 2; then compounds 1 and 3 (each within the scatter of the next).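

In this assay, the benzyl ring carried on the saturated chain carbon bound to a sulfur proves able to move the number upward as well as downward, with a number 20.5 percentage points higher from compound 2 to compound 3 (beyond the scatter) as the second step seen at this place. Set beside it, a number 7.7 percentage points higher from compound 1 to compound 3 (within the scatter) means that 4-fluorophenyl and 2-chlorophenyl cannot be told apart here, so among the three compounds only the 3-chlorophenyl of compound 2 stands apart. No independent information bears on why the number shifts with this change.

The compounds shown change the halogen and its ring position together, so they leave open which of the two goes with the low number of compound 2. Neither an unsubstituted phenyl, a 4-chlorophenyl nor a 3-fluorophenyl group is among them, and any of these would separate the two.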